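The source may hold more compounds than are shown below. What is called first, only, known or untested is meant among the compounds shown, and "the series" means these compounds.

Three compounds that share one core and differ only in one aromatic substituent have been measured: compound 1 `C[C@H]1CC[C@@H]2[C@@H](OC(=O)[C@]23CC(c2ccc(Cl)cc2)N(c2ccccc2)O3)[C@]2(C)C(=O)C=C[C@@]12O`, compound 2 `C[C@H]1CC[C@@H]2[C@@H](OC(=O)[C@]23CC(c2ccc(F)cc2)N(c2ccccc2)O3)[C@]2(C)C(=O)C=C[C@@]12O` and compound 3 `C[C@H]1CC[C@@H]2[C@@H](OC(=O)[C@]23CC(c2ccccc2)N(c2ccccc2)O3)[C@]2(C)C(=O)C=C[C@@]12O`. In a physicochemical assay for lipophilicity (a higher number here means a more lipophilic compound, a lower number a more polar compound), compound 3 gives 3.19, which cannot be told apart from compound 2 at 3.35, while compound 1 stands clearly higher at 3.87. The next structure, compound 4 `C[C@H]1CC[C@@H]2[C@@H](OC(=O)[C@]23CC(c2c(F)cccc2F)N(c2ccccc2)O3)[C@]2(C)C(=O)C=C[C@@]12O`, brings 2,6-difluorophenyl in place of phenyl on a saturated ring carbon. For the measured compounds named here, the closest guide is the single fluoro step, a number 0.16 log units lower from compound 2 to compound 3 (within the scatter). Going by the values given here, no measured compound carries 2,6-difluorophenyl, so the guide is only partial. In this assay the expected step is small and upward, a number 0.21 log units higher from compound 3 to compound 4 (within the scatter). The estimate for compound 4 is 3.4, with a range from 3.05 to 3.75.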

Compound 4, partition coefficient: 3.42
Estimate against measurement, compound 4: 0.02 log units below; the range from low to high includes it.
By their numbers in this assay, from the lowest: compounds 3, 2 and 4 (each within the scatter of the next); then compound 1.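

In this assay, the 2,6-difluorophenyl group at this saturated ring carbon cannot be told apart from either phenyl ((a number 0.23 log units higher from compound 3 to compound 4 (within the scatter))) or 4-fluorophenyl ((a number 0.07 log units higher from compound 2 to compound 4 (within the scatter))). The 4-chlorophenyl group remains separate from it ((a number 0.45 log units lower from compound 1 to compound 4 (beyond the scatter))), so among these four compounds, only compound 1 stands apart from the others. Nothing available explains why these groups compare as they do.

Open, from the compounds shown here alone, is whether a carboxylic acid or an amine on this aromatic ring would shift the number beyond the scatter. Also open, going by these compounds, is what a change to the phenyl on the ring nitrogen would do.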